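One Swap on the Benzyl Group: 4-Fluorophenyl to 1H-Indazol-6-yl

The source may hold more compounds than are shown below. What is called first, only, known or untested is meant among the compounds shown, and "the series" means these compounds.

Measured so far:
compound 1 `O=C(Nc1ccc(-c2cscn2)cc1)C1CCCN(S(=O)(=O)c2ccc(F)c(F)c2)C1`: > 20000 nM (a limit of the assay, not a number)
compound 2 `O=C(Nc1ccc(-c2cscn2)cc1)C1CCCN(Cc2ccc(F)cc2)C1`: 2250 nM

Both were tested in a functional assay on A-375 cells (Homo sapiens) for antiproliferative activity; on this read-out lower numbers stand for stronger inhibition and higher numbers for weaker inhibition. For compound 1 the assay reports only a limit, > 20000 nM, and no number (the limit of > 20000 nM in this assay, at which 1 of the 2 values shown sits). Going by the values given here, compound 2 gives 2250 nM, which is the only actual number in this set, so compound 2 stands as the one fixed point. Compound 3 `O=C(Nc1ccc(-c2cscn2)cc1)C1CCCN(Cc2ccc3cn[nH]c3c2)C1` differs from compound 2 in a single place: 1H-indazol-6-yl in place of 4-fluorophenyl on a saturated chain carbon bound to an amine nitrogen in a ring. Among the compounds with values here, no measured pair shows this kind of change, so the size and direction of its effect cannot be read from the data at hand. A modest gain is expected, a 1.5-fold lower number from compound 2 to compound 3 (0.18 log units; within the scatter), not clearly beyond the usual scatter. Compound 3 is therefore estimated at 1500 nM, with a plausible range from 300 nM to 8000 nM.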

Compound 3, half-maximal inhibitory concentration: > 20000 nM
Compound 3: a limit, no number (the forecaster's own chance of this, stated with the estimate: 10%); middle value at least 13-fold (1.12 log units) away from the limit.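

In this assay compound 3 gives > 20000 nM, which is a limit of the assay and not a number. The swap of 4-fluorophenyl for 1H-indazol-6-yl gives an at least 8.8-fold higher number from compound 2 to compound 3 (0.94 log units; beyond the scatter), the first measured sign that activity at this saturated chain carbon depends on which aromatic group it carries, and that this larger group with a hydrogen-bond donor is not tolerated here. Only a minimum for the loss can be read, as the series has reached the edge of what the assay can report: the limit of > 20000 nM in this assay, at which 2 of the 3 values shown sit.

The compounds shown do not separate the effect of the added ring from that of its nitrogens, and a naphthyl group, built of carbon only, would speak to that. Going by these compounds, whether plain phenyl or pyridinyl on the same carbon would match or improve on compound 2 also remains open.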